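Adding a chloro group to a diaryl urea

The source may report more compounds than this note shows. Statements on the series, on what has been measured and on what is new or still open speak of the compounds shown alone.

Measured in a functional assay on MDA-MB-231 cells (Homo sapiens) for inhibition, read by MTT assay and WST assay, with a stated time of 72 h, tested at 10 uM; a lower number here means less inhibition of growth, a higher number more inhibition of growth at the concentration tested:
compound 1 `O=C(Nc1ccccc1)Nc1ccc(Oc2ccc(-c3ncc[nH]3)cc2)cc1`: 11.4%
compound 2 `O=C(Nc1ccc(Oc2ccc(-c3ncc[nH]3)cc2)cc1)Nc1cccc(C(F)(F)F)c1`: 28.1%

Within the data shown here, in this set compound 2 stands highest of the two numbers; the only measured step, a number 16.7 percentage points higher from compound 1 to compound 2 (beyond the scatter), lies beyond the scatter. Compound 3 `O=C(Nc1ccc(Oc2ccc(-c3ncc[nH]3)cc2)cc1)Nc1cc(C(F)(F)F)ccc1Cl` differs from compound 2 by chloro in place of hydrogen on an aromatic carbon. Among the measured compounds shown here, no measured step involves a chloro group; the one known step concerns a different group on the same ring and gives little guidance. For compound 3 a small rise, or none beyond the scatter, is expected, a number 6.9 percentage points higher from compound 2 to compound 3 (within the scatter). Compound 3 is estimated at 35%, within 15% to 60%.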

Compound 3, percent growth inhibition at one concentration: 32.3%
Beside the measured number, compound 3's estimate is 2.7 percentage points above it, and the stated range covers the measured number.
By their numbers in this assay, from the lowest: compound 1; then compounds 2 and 3 (each within the scatter of the next).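

In this assay, chloro in place of hydrogen on this carbon, ortho to a large group and para to a trifluoromethyl group, gives a step that cannot be told from no change (a number 4.2 percentage points higher from compound 2 to compound 3 (within the scatter)). The full 2-chloro-5-(trifluoromethyl)phenyl group in place of phenyl gives a step that remains clear of the scatter (a number 20.9 percentage points higher from compound 1 to compound 3 (beyond the scatter)). No available evidence explains either step. Going by these compounds, whether a methoxy group or an amine on the same carbon would give a larger step remains open. So does whether chloro alone, without trifluoromethyl, would change the number.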